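Pyridin-4-yl in place of furan-2-yl: working notes

The compounds below may be only part of what the source reports. "The series", "measured", "known", "first", "only" and "open" are said of these compounds alone.

In a physicochemical assay for activation, with a stated time of 60 min (a lower number here means that less compound is needed, a higher number that more compound is needed for the effect), compound 1 `CCCCCc1ccc(/C=C2\C(=O)NC(=O)C3=C2CCCC3)cc1` gives 9200 nM. Compound 2 `O=C1NC(=O)/C(=C\c2ccco2)C2=C1CCCC2` gives 18000 nM, and these two values lie within the scatter of each other. Compound 3 `O=C1NC(=O)/C(=C\c2ccncc2)C2=C1CCCC2` carries pyridin-4-yl in place of furan-2-yl on a double-bonded chain carbon bound to a double-bonded ring carbon. Among the compounds with values here, no measured pair differing in one place exists to size this change, so no shift beyond the scatter is expected, in either direction. The expected step is a 1.1-fold higher number from compound 2 to compound 3 (0.05 log units; within the scatter). Compound 3 is estimated at 20000 nM, with an expected range of 7000 nM to 60000 nM.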

Compound 3, half-maximal effective concentration: 95000 nM
For compound 3 the middle estimate is 4.8-fold (0.68 log units) below the measured one; measured number outside the range, above it.
By their numbers in this assay, from the lowest: compounds 1 and 2 (each within the scatter of the next); then compound 3.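

In this assay, pyridin-4-yl in place of furan-2-yl on a double-bonded chain carbon bound to a double-bonded ring carbon gives a 5.3-fold higher number from compound 2 to compound 3 (0.72 log units; beyond the scatter) and so shows that this position does not treat the two aromatic rings alike. Within the data shown here, it is the first step that sizes a change here, and it lies beyond the scatter. Nothing at hand bears on the reason for this step.

Going by these compounds, whether ring size or the identity of the hetero atom carries the step stays open. An unsubstituted phenyl or a pyridin-3-yl at this place would help to separate the two.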